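The source may report more compounds than this note shows. Statements on the series, on what has been measured and on what is new or still open speak of the compounds shown alone.

Measured in a functional assay on HCT-116 cells (Homo sapiens) for antiproliferative activity, read by MTT assay, with a stated time of 48 h; a lower number here means a stronger inhibitor, a higher number a weaker inhibitor:
- compound 1 `COC(=O)c1ccc(N2CC3(CCN(C(=O)c4cc(C)c5[nH]ncc5c4)CC3)CC2=O)cc1`: > 10000 nM, a limit of the assay and not a number
- compound 2 `Cc1cc(C(=O)N2CCC3(CC2)CC(=O)N(c2ccc(C(F)(F)F)cc2)C3)cc2cn[nH]c12`: 8670 nM
- compound 3 `O=C(c1ccc2[nH]c(-c3ccccc3)nc2c1)N1CCC2(CC1)CC(=O)N(c1ccc(C(F)(F)F)cc1)C2`: 1220 nM

Compound 2 reads 8670 nM and compound 3 reads 1220 nM, the lower of these two numbers, with a gap beyond the scatter. Compound 4 `CC(C)c1ccc(-c2nc3cc(C(=O)N4CCC5(CC4)CC(=O)N(c4ccc(C(F)(F)F)cc4)C5)ccc3[nH]2)cc1` has isopropyl in place of hydrogen on an aromatic carbon, para to a large group, turning phenyl into 4-isopropylphenyl (isopropyl in place of hydrogen on an aromatic carbon). Among the compounds with values here, the one measured step, an at least 1.1-fold lower number from compound 1 to compound 2 (0.06 log units; that floor lies within the scatter), replaces a different group, so it does not bear on this change. With no measured guide, no step beyond the scatter is expected in this assay. The expected step is a 1.2-fold lower number from compound 3 to compound 4 (0.09 log units; within the scatter). For compound 4 the estimate is 1000 nM, with an expected range from 300 nM to 4000 nM.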

Compound 4, half-maximal inhibitory concentration: 6210 nM
Estimate against measurement, compound 4: 6.2-fold (0.79 log units) below; measured number outside the range, above it.
By their numbers in this assay, from the lowest: compound 3; then compounds 4 and 2 (each within the scatter of the next). At a limit, above all of these: compound 1.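

In this assay, turning phenyl into 4-isopropylphenyl gives a 5.1-fold higher number from compound 3 to compound 4 (0.71 log units; beyond the scatter), so what sits on this aromatic carbon, para to a large group, does matter. Among the compounds shown, this is the only change made on that phenyl, and here adding isopropyl moves the number the wrong way, towards a weaker inhibitor. As far as these compounds go, whether methyl, an amine or a carboxylic acid in the same place would also raise the number remains open. The compounds shown give no reason for this loss.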